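A few compounds are considered here, and "the series" means these few. Any claim that something is new, unique, unknown or untested is made for them only; others in the source may bear on it.

All four compounds share one core: a five-membered aromatic ring with one nitrogen and one oxygen, carrying a ketone with a chain that ends in a phenyl ring on one side and a varying aromatic group on the other. Compound 1 `Nc1cccc(-c2cnc(C(=O)CCCCCCc3ccccc3)o2)c1` bears a 3-aminophenyl there, and in an assay (Rattus norvegicus) for inhibition of Fatty-acid amide hydrolase 1 (Homo sapiens) (a higher number here means a weaker inhibitor, a lower number a stronger inhibitor), compound 1 gives 19 nM. Compound 2 `N#Cc1cccc(-c2cnc(C(=O)CCCCCCc3ccccc3)o2)c1` bears a 3-cyanophenyl, and in this assay compound 2 gives 15 nM; the step of a 1.3-fold lower number from compound 1 to compound 2 (0.10 log units; within the scatter) is within the scatter. Compound 3 `O=C(CCCCCCc1ccccc1)c1ncc(-c2ncccc2C(=O)O)o1` bears a 3-carboxypyridin-2-yl. For compound 3 this assay reports only a limit, > 50 nM, so its true number is not known beyond (the limit of > 50 nM in this assay, at which 1 of the 3 values shown sits). The steps of an at least 2.6-fold higher number from compound 1 to compound 3 (0.42 log units; beyond the scatter) and an at least 3.3-fold higher number from compound 2 to compound 3 (0.52 log units; beyond the scatter) show that the 3-carboxypyridin-2-yl gives a weaker result than either substituted phenyl.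

Compound 4 `O=C(CCCCCCc1ccccc1)c1ncc(-c2cncnc2)o1` makes the change (pyrimidin-5-yl in place of 3-carboxypyridin-2-yl on an aromatic carbon). Within the data shown here, both measured steps onto this position bear on it, and both point away from the 3-carboxypyridin-2-yl; pyrimidin-5-yl itself appears on no measured compound. The expected step is therefore an at least 1.4-fold lower number from compound 3 to compound 4 (0.15 log units; that floor lies within the scatter), a return toward the numbers of compound 1 and compound 2, though with wide uncertainty. Compound 4 is estimated at 35 nM in this assay, with a likely range from 10 nM to 150 nM.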

Compound 4, inhibition constant: 22 nM
Beside the measured number, compound 4's estimate is 1.6-fold (0.20 log units) above it; measured number inside the range.
By their numbers in this assay, from the lowest: compounds 2, 1 and 4 (each within the scatter of the next). At a limit, above all of these: compound 3.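

The change to pyrimidin-5-yl brings an at least 2.2-fold lower number from compound 3 to compound 4 (0.35 log units; beyond the scatter) in this assay and so shows that a six-membered aromatic ring with hetero atoms can sit at this position without the loss seen with the 3-carboxypyridin-2-yl. With a 1.5-fold higher number from compound 2 to compound 4 (0.17 log units; within the scatter) and a 1.2-fold higher number from compound 1 to compound 4 (0.06 log units; within the scatter) the pyrimidin-5-yl matches the two substituted phenyls, so neither a phenyl ring nor an amino or cyano group is needed here for a number of this size. The true size of the first step stays unknown, because compound 3 is known only as a limit: the limit of > 50 nM in this assay, at which 1 of the 4 values shown sits.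

On these data alone, it remains open whether the weaker result of compound 3 belongs to its carboxylic acid or to the pyridine ring that carries the acid. A carboxylic acid on a phenyl ring, or a pyridine ring with no acid, would help to tell these two readings apart.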